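The source may hold more compounds than are shown below. What is called first, only, known or untested is meant among the compounds shown, and "the series" means these compounds.

Notes on the series. Compound 1 `C/N=C(\S)OC[C@H]1OC(n2cnc3c(NC4CCOC4)nc(Cl)nc32)[C@H](O)[C@@H]1O` gives 71 nM in an assay on DDT1 cells (Cricetulus griseus) for binding affinity to adenosine receptor A1 (Homo sapiens), read by radioligand binding; on this read-out lower numbers stand for stronger inhibition and higher numbers for weaker inhibition. Within the data shown here, compound 2 `CC/N=C(\S)OC[C@H]1OC(n2cnc3c(NC4CCOC4)nc(Cl)nc32)[C@H](O)[C@@H]1O` gives 55 nM in this assay; the step of a 1.3-fold lower number from compound 1 to compound 2 (0.11 log units; within the scatter) is the only single-point step measured so far. Compound 3 `CCC/N=C(\S)OC[C@H]1OC(n2cnc3c(NC4CCOC4)ncnc32)[C@H](O)[C@@H]1O` gives 50 nM in this assay. Its number is the lowest of the three, yet the gaps to compound 2 and to compound 1 are both within the scatter, so the three compounds cannot be told apart on this read-out.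

Compound 4 `O=C(NC1CCC1)OC[C@H]1OC(n2cnc3c(NC4CCOC4)ncnc32)[C@H](O)[C@@H]1O` is the next to be measured. It differs from compound 3 in one place: a group of 7 heavy atoms (5 carbon, 1 nitrogen, 1 oxygen; one four-membered non-aromatic ring of carbon only) in place of a group of 6 heavy atoms (4 carbon, 1 nitrogen, 1 sulfur; no ring), on an oxygen on a saturated carbon. Among the measured compounds shown here, no measured step covers this exchange. For the measured compounds named here, the one step that is measured, a 1.3-fold lower number from compound 1 to compound 2 (0.11 log units; within the scatter), lies within the group that leaves and stays within the scatter. The values of compound 1, compound 2 and compound 3 together show that varying the group on an oxygen on a saturated carbon has so far left the number about where it is. The exchange in compound 4 is larger than any measured one, so the uncertainty is wider, but the expected step of a 1.2-fold higher number from compound 3 to compound 4 (0.08 log units; within the scatter) in this assay is none beyond the scatter. Compound 4 is therefore estimated at 60 nM in this assay, with a range from 20 nM to 200 nM.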

Compound 4, inhibition constant: 306 nM
Estimate against measurement, compound 4: 5.1-fold (0.71 log units) below; measured number outside the range, above it.
By their numbers in this assay, from the lowest: compounds 3, 2 and 1 (each within the scatter of the next); then compound 4.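

In this assay, among these compounds, a 6.1-fold higher number from compound 3 to compound 4 (0.79 log units; beyond the scatter) is the first step that lies beyond the scatter, so the group on an oxygen on a saturated carbon is not as free to vary as a 1.3-fold lower number from compound 1 to compound 2 (0.11 log units; within the scatter) alone suggested. The step appears although the counts of hydrogen-bond donors, hydrogen-bond acceptors and double bonds outside aromatic rings are the same in the group that leaves and in cyclobutylcarbamoyl, while the entering group holds oxygen and a four-membered non-aromatic ring and the leaving group holds sulfur and no ring. Nothing measured on these compounds gives a reason for this step.

The exchange changes the ring and the heteroatom together, so the compounds shown do not tell which of the two goes with the higher number. From the compounds shown here alone, a propylcarbamoyl group would keep the open chain of compound 3 with the oxygen of compound 4, and a cyclopentylcarbamoyl group would test the ring size, so how either would read at this position remains open.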